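The source may report more compounds than this note shows. Statements on the series, on what has been measured and on what is new or still open speak of the compounds shown alone.

Measured compounds and their values:
Compound 1, `COc1ccc(-c2ccnc(C(=O)Nc3ccc(Oc4ccnc5[nH]ccc45)cc3)n2)cc1`, gives 13300 nM.
Compound 2, `O=C(Nc1ccc(Oc2ccnc3[nH]ccc23)cc1)c1nccc(-c2ccc(Cl)cc2)n1`, gives 22400 nM.
Compound 3, `COc1ccc(-c2ccnc(C(=O)Nc3ccc(Oc4ccnc5[nH]ccc45)c(F)c3)n2)cc1`, gives 5430 nM.

These three compounds were tested in a functional assay on A549 cells (Homo sapiens) for cytotoxicity, read by MTT assay, with a stated time of 72 h; on this read-out lower numbers stand for stronger inhibition and higher numbers for weaker inhibition. Compound 1 and compound 2 share a core and differ only in one place: chloro in place of methoxy on an aromatic carbon. That change gave a 1.7-fold higher number from compound 1 to compound 2 (0.23 log units; within the scatter), so the two values cannot be told apart with confidence.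

Compound 3 differs from compound 1 in its core: fluoro in place of hydrogen on an aromatic carbon. That change gave a 2.4-fold lower number from compound 1 to compound 3 (0.39 log units; beyond the scatter). Compound 3 therefore carries the lowest number among the three, and its step to compound 2 is also beyond the scatter.

Compound 4, `O=C(Nc1ccc(Oc2ccnc3[nH]ccc23)c(F)c1)c1nccc(-c2ccc(Cl)cc2)n1`, has not yet been measured in this assay. It is built from compound 3 by the same change that was made from compound 1 to compound 2: chloro in place of methoxy on an aromatic carbon. The place where the change happens is described in the same words in both cases, so the change is the same one, applied to a core that carries the fluoro.

Because the earlier occurrence of this change gave a 1.7-fold higher number from compound 1 to compound 2 (0.23 log units; within the scatter), the step from compound 3 to compound 4 is expected to be of a similar small size, a 1.7-fold higher number from compound 3 to compound 4 (0.23 log units; within the scatter), well within what repeated measurements would show. This expectation rests on a single prior example, so it is held loosely. For compound 4 the estimated value is 9200 nM, with a likely range from 4500 nM to 20000 nM.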

Compound 4, half-maximal inhibitory concentration: 8940 nM
Compound 4: the middle estimate sits 1.0-fold (0.01 log units) above what was measured; low and high end bracket the measured number.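

In this assay, chloro in place of methoxy on the core that carries the fluoro gave a 1.6-fold higher number from compound 3 to compound 4 (0.22 log units; within the scatter), and this matches the same change on the core without the fluoro: the same change on two cores in this assay, a 1.7-fold higher number (0.23 log units; within the scatter) from compound 1 to compound 2 and a 1.6-fold higher number (0.22 log units; within the scatter) from compound 3 to compound 4, 1.0-fold (0.01 log units) apart, within the scatter of two such steps. Fluoro in place of hydrogen gave a 2.5-fold lower number from compound 2 to compound 4 (0.40 log units; beyond the scatter), which likewise matches its earlier step on the methoxy compounds: the same change on two cores in this assay, a 2.4-fold lower number (0.39 log units; beyond the scatter) from compound 1 to compound 3 and a 2.5-fold lower number (0.40 log units; beyond the scatter) from compound 2 to compound 4, 1.0-fold (0.01 log units) apart, within the scatter of two such steps. Within these four compounds, each change therefore kept its size whichever form the other place took, so the two changes behaved as independent of each other; this does not show that chloro and methoxy truly differ, since both of their steps lie within the scatter, and it does not show why either change acts as it does or that the same would hold on any other core.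

The compounds shown leave open whether another group on the aromatic ring, such as an amine or a carboxylic acid in place of the chloro or methoxy, would keep the step from the fluoro at the same size. They also leave open whether a chloro or a methyl in place of that fluoro would act the same way on both cores.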